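The source may report more compounds than this note shows. Statements on the series, on what has been measured and on what is new or still open speak of the compounds shown alone.

In a functional assay on A549 cells (Homo sapiens) for inhibition, read by MTT assay, with a stated time of 48 h (a higher number here means a weaker inhibitor, a lower number a stronger inhibitor), compound 1 (`COc1ccc(N(C)c2nc(C)nc3ccccc23)cc1C(=O)OCC[Se]C#N`) gives 353 nM and stands second highest of the three numbers in hand. Compound 2 (`COc1ccc(N(C)c2nc(C)nc3ccccc23)cc1[Se]C`) lies lower at 11 nM and compound 3 (`COc1ccc(N(C)c2nc(C)nc3ccccc23)cc1OCCCC[Se]C#N`) lies higher at 1200 nM in the same read-out. Compound 4 (`COc1ccc(N(C)c2nc(C)nc3ccccc23)cc1C(=O)OCCCCCC[Se]C#N`) has no number yet and differs from compound 1 by one change (a group of 7 heavy atoms (5 carbon, 1 nitrogen, 1 selenium; no ring) in place of a group of 3 heavy atoms (1 carbon, 1 nitrogen, 1 selenium; no ring), on a saturated chain carbon, two bonds along the chain from an oxygen next to a carbonyl group) on the chain. Going by the values given here, no measured pair alters this chain alone, so the evidence is indirect. The closest guide is the modest step (a 3.4-fold higher number from compound 1 to compound 3 (0.53 log units; beyond the scatter)) to a group of 8 heavy atoms on the aromatic carbon, although that step replaces the whole group. The large step (a 32-fold lower number from compound 1 to compound 2 (1.51 log units; beyond the scatter)) leaves a group of 2 heavy atoms there and says little about a longer chain. The step expected in this assay is therefore modest and upward (a 2.3-fold higher number from compound 1 to compound 4 (0.36 log units; beyond the scatter)) but remains poorly constrained. Compound 4 is estimated at 800 nM as a central value, with an expected range from 200 nM to 3000 nM on this indirect evidence.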

Compound 4, half-maximal inhibitory concentration: 488 nM
The estimate for compound 4 lay 1.6-fold (0.21 log units) above the measured number; the measured number falls inside the stated range.
By their numbers in this assay, from the lowest: compound 2; then compounds 1 and 4 (each within the scatter of the next); then compound 3.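

Going by these compounds alone, this is the first pair to alter the chain alone: a group of 7 heavy atoms in place of a group of 3 heavy atoms, on a saturated chain carbon, two bonds along the chain from an oxygen next to a carbonyl group, gives a 1.4-fold higher number from compound 1 to compound 4 (0.14 log units; within the scatter) in this assay. At this position, the two chains shown are therefore not separated by this read-out, with the nitrile-bearing selenium end and the carbonyl link held constant. No supporting data are available to account for this result.

Open, on these data alone, is whether a longer chain than that of compound 4 would stay within the scatter of compound 1. Also open, as far as these compounds go, is whether an amine or a carboxylic acid in place of the selenium-bearing end would leave the number similarly unchanged.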